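This account rests on a few compounds, and the source may have more. Where it says the series, first, only, none or still open, it means among the compounds named here.

Working notes on the series. In a physicochemical assay for solubility, read by nephelometry, in phosphate buffer, measured as kinetic solubility, at pH 6.5 (on this read-out lower numbers stand for lower solubility and higher numbers for higher solubility), compound 1 `O=C(Nc1ccc(F)c(-c2nc3ncccc3o2)c1)c1cnco1` gives 6.3 ug/mL and compound 2 `O=C(Nc1ccc(F)c(-c2nc3ncccc3o2)c1)c1ccoc1` gives 6.3 ug/mL, so compound 2 stands level with compound 1. Compound 3 `Cc1ccoc1C(=O)Nc1ccc(F)c(-c2nc3ncccc3o2)c1` has not yet been measured. It carries 3-methylfuran-2-yl in place of furan-3-yl on a carbonyl carbon. Among the compounds with values here, the one measured step at this place is no change at the digits printed from compound 1 to compound 2 (within the scatter), with furan-3-yl in place of 1,3-oxazol-5-yl. Within the data shown here, it is a single step, and no measured compound carries 3-methylfuran-2-yl, so the evidence is thin and gives no direction. Among the measured compounds shown here, with only that step as a guide, the change in this assay is expected to be no larger than the scatter, and the step of no change at the digits printed from compound 2 to compound 3 (within the scatter) is the expected outcome. Compound 3 is estimated at 6.3 ug/mL, with an expected range of 3 ug/mL to 13 ug/mL.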

Compound 3, solubility: 1.6 ug/mL
Beside the measured number, compound 3's estimate is 3.9-fold (0.60 log units) above it, and the stated range ends above it.
By their numbers in this assay, from the lowest: compound 3; then compounds 1 and 2 (each within the scatter of the next).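

In this assay the group on this carbonyl carbon, whose other neighbour is the amide-type nitrogen, is not a silent place in the series: 3-methylfuran-2-yl in place of furan-3-yl gives a 3.9-fold lower number from compound 2 to compound 3 (0.60 log units; beyond the scatter), and in place of 1,3-oxazol-5-yl it gives a 3.9-fold lower number from compound 1 to compound 3 (0.60 log units; beyond the scatter). Within the data shown here, the earlier pair showed only one exchange of five-membered aromatic rings with no change beyond the scatter, so compound 3 is the first sign that this position can move the read-out. Nothing at hand bears on the reason for this step.

The step from compound 2 to compound 3 changes both the ring's point of attachment and the methyl group, and the compounds shown do not separate the two. From the compounds shown here alone, whether plain furan-2-yl stays level with compound 2, and how an amine or a carboxylic acid on the ring would read, remains open.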